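The source may hold more compounds than are shown below. What is called first, only, known or untested is meant among the compounds shown, and "the series" means these compounds.

Compound 1 `COc1cc(NC(=O)Nc2cc(Nc3ccc(C)c(C)c3)ncn2)cc(OC)c1` gives 45.3% in a functional assay on NCI-H226 cells (Homo sapiens) for inhibition, read by MTT assay, with a stated time of 48 h, tested at 10 uM (a higher number here means more inhibition at the concentration tested (going by the name of the read-out), a lower number less inhibition), and compound 2 `COc1cc(NC(=O)Nc2cc(Nc3cc(F)ccc3OC)ncn2)cc(OC)c1` gives 37.7% in this assay, the lower of the two numbers measured, though the step of a number 7.6 percentage points lower from compound 1 to compound 2 (within the scatter) lies within the scatter. Compound 3 `CCc1cccc(Nc2cc(NC(=O)Nc3cc(OC)cc(OC)c3)ncn2)c1` differs from compound 2 in one place: 3-ethylphenyl in place of 5-fluoro-2-methoxyphenyl on a nitrogen on an aromatic ring. Among the compounds with values here, the only step that bears on this, an earlier swap of the group on the same nitrogen, stayed within the scatter, so a change no larger than the scatter is expected here, in no fixed direction. For compound 3 the expected result in this assay is 41%, within 25% to 57%, meaning an estimated step of a number 3.3 percentage points higher from compound 2 to compound 3 (within the scatter).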

Compound 3, a percentage reported as inhibition, at one concentration (the size of the read-out at that concentration, not a potency): 36.7%
Beside the measured number, compound 3's estimate is 4.3 percentage points above it, within the range that was stated.
By their numbers in this assay, from the lowest: compounds 3, 2 and 1 (each within the scatter of the next).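

In this assay, replacing the 5-fluoro-2-methoxyphenyl group with 3-ethylphenyl, which has no oxygen or fluorine, gives a number 1 percentage points lower from compound 2 to compound 3 (within the scatter), and replacing 3,4-dimethylphenyl with 3-ethylphenyl gives a number 8.6 percentage points lower from compound 1 to compound 3 (within the scatter). All three phenyl groups on this nitrogen therefore read alike here, whether they carry only carbon or also oxygen and fluorine. No measured evidence bears on what lies behind these numbers.

Still open, going by these compounds, is whether a phenyl ring carrying a carboxylic acid or an amine on this nitrogen would read differently. The same question applies to a plain alkyl chain in place of the ring.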